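This account rests on a few compounds, and the source may have more. Where it says the series, first, only, none or still open, it means among the compounds named here.

Compound 1 `O=c1cc(-c2ccc(O)c(O)c2)oc2cc(O)ccc12` gives 11000 nM in a functional assay for inhibition, with Rattus norvegicus as the target, using microsomes; on this read-out higher numbers stand for weaker inhibition and lower numbers for stronger inhibition. Compound 2 `COc1ccc2c(=O)cc(-c3ccc(O)c(O)c3)oc2c1` gives 2500 nM in this assay, and compound 3 `O=c1cc(-c2ccc(O)c(O)c2)oc2cc(OCCO)ccc12` gives 16400 nM in this assay. Compound 3 stands highest of the three numbers, though its step from compound 1 is within the scatter, a 1.5-fold higher number from compound 1 to compound 3 (0.17 log units; within the scatter), while its step from compound 2 lies beyond it, a 6.6-fold higher number from compound 2 to compound 3 (0.82 log units; beyond the scatter). Compound 4 `C[N+](C)(C)CCCOc1ccc2c(=O)cc(-c3ccc(O)c(O)c3)oc2c1` differs from compound 3 by a group of 5 heavy atoms (4 carbon, 1 nitrogen; no ring) in place of one oxygen atom, on a saturated chain carbon, two bonds along the chain from an oxygen on an aromatic ring. For the measured compounds named here, the only measured step touching this chain is a 6.6-fold higher number from compound 2 to compound 3 (0.82 log units; beyond the scatter), where hydroxymethyl entering raised the number. Going by the values given here, no measured step replaces a hydroxy with a charged group, so the expectation is weak and a small shift is expected. In this assay the expected step is a 1.1-fold lower number from compound 3 to compound 4 (0.04 log units; within the scatter). Compound 4 is expected to give 15000 nM, within 5000 nM to 45000 nM.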

Compound 4, half-maximal inhibitory concentration: 37300 nM
For compound 4 the middle estimate is 2.5-fold (0.40 log units) below the measured one, within the range that was stated.
By their numbers in this assay, from the lowest: compound 2; then compounds 1 and 3 (each within the scatter of the next); then compound 4.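

In this assay, the charged group in place of the hydroxy raises the number (a 2.3-fold higher number from compound 3 to compound 4 (0.36 log units; beyond the scatter)), whereas the hydroxy-ended chain of compound 3 had not separated from compound 1. The charged chain is also the first substituent on this oxygen to stand clearly above the free hydroxy (a 3.4-fold higher number from compound 1 to compound 4 (0.53 log units; beyond the scatter)), and it gives the largest step from the methyl ether (a 15-fold higher number from compound 2 to compound 4 (1.17 log units; beyond the scatter)). Nothing available explains this rise. From the compounds shown here alone, whether the charge or the size of the group carries the step stays open: an uncharged tertiary amine on the same chain, or a carboxylic acid, would help separate the two.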